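The source may report more compounds than this note shows. Statements on the series, on what has been measured and on what is new or still open speak of the compounds shown alone.

Working notes on the series. Two compounds have been run in an ADME assay on Huh-7 cells (Homo sapiens) for cytotoxicity, with a stated time of 72 h (on this read-out lower numbers stand for higher toxicity in this test and higher numbers for lower toxicity in this test), so far, and neither returned a number. Compound 1 `CS(=O)(=O)Nc1ccc2c(c1)S(=O)(=O)N=C(C1=C(O)C3CCCCCCC3N(Cc3ccc(F)cc3)C1=O)N2` gives in this assay > 33000 nM, which is a limit of the assay and not a measured value. Compound 2 `CS(=O)(=O)Nc1ccc2c(c1)S(=O)(=O)N=C(C1=C(O)[C@H]3CCC[C@H]3N(Cc3ccc(F)c(F)c3)C1=O)N2` gives in this assay > 1000 nM, again a limit rather than a number. Where compound 2 stands can therefore only be stated as a boundary: its value sits at the limit of > 1000 nM in this assay, at which 1 of the 2 values shown sits, while the other value sits at the limit of > 33000 nM in this assay, at which 1 of the 2 values shown sits, and no step between the two can be counted, since both are limits.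

Compound 3 `CS(=O)(=O)Nc1ccc2c(c1)S(=O)(=O)N=C(C1=C(O)[C@H]3CCC[C@H]3N(CC3CC3)C1=O)N2` has not been measured in this assay. It differs from compound 2 by cyclopropyl in place of 3,4-difluorophenyl on a saturated chain carbon bound to an amide-type nitrogen in a ring. Within the data shown here, with no measured step to lean on, no shift beyond the usual scatter is expected from this change in this assay; the step from compound 2 to compound 3 is estimated as a step that the limit leaves unreadable from compound 2 to compound 3. For compound 3 the estimate in this assay is 30000 nM, within a range of 5000 nM to 100000 nM, most likely again reported only as a limit.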

Compound 3, half-maximal cytotoxic concentration: > 33000 nM
Compound 3: no number, only a limit; the forecaster's own chance of this, stated with the estimate: 80%; middle value at least 1.1-fold (0.04 log units) away from the limit.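

In this assay compound 3 gives > 33000 nM, which is a limit of the assay and not a number. Among these compounds, compound 2 gives > 1000 nM, also a limit, so no step between compound 2 and compound 3 can be read. The compounds shown leave open whether cyclopropyl in place of 3,4-difluorophenyl changes the half-maximal cytotoxic concentration at all.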